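The source may report more compounds than this note shows. Statements on the series, on what has been measured and on what is new or still open speak of the compounds shown alone.

Of the compounds shown here, three built on one shared core have been tested in a functional assay on HeLa cells (Homo sapiens) for antiproliferative activity, read by MTT assay, with a stated time of 48 h (on this read-out higher numbers stand for an effect only at larger amounts of compound and lower numbers for an effect already at smaller amounts), which follows how strongly a compound holds back the growth of cultured human cells. Compound 1 `O=C(Nc1nnc(-c2ccc3c(c2)OCCO3)s1)c1ccccc1` carries a phenyl on the carbonyl carbon, and in this assay compound 1 gives only a limit of the measurement, > 100 ug/mL. Compound 2 `O=C(CCc1ccccc1)Nc1nnc(-c2ccc3c(c2)OCCO3)s1` carries a phenethyl at the same place, and in this assay compound 2 gives 32.5 ug/mL. Compound 3 `O=C(Nc1nnc(-c2ccc3c(c2)OCCO3)s1)c1ccccn1` carries a pyridin-2-yl there, and in this assay compound 3 again gives only a limit, > 100 ug/mL. The step of an at least 3.0-fold lower number from compound 1 to compound 2 (0.48 log units; beyond the scatter) lies beyond the scatter, as does the step of an at least 3.0-fold higher number from compound 2 to compound 3 (0.48 log units; beyond the scatter). The step that the two limits leave unreadable from compound 1 to compound 3 cannot be sized because both values sit at the same limit (the limit of > 100 ug/mL in this assay, at which 2 of the 3 values shown sit). Compound 3 therefore stands at the edge of what this assay can report, alongside compound 1.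

Compound 4 `O=C(Nc1nnc(-c2ccc3c(c2)OCCO3)s1)c1ccncc1` differs from compound 3 by pyridin-4-yl in place of pyridin-2-yl on a carbonyl carbon. Going by the values given here, none of the measured steps moves a ring nitrogen from one position to another, so there is no direct guide for this change. Given that compound 3 gives > 100 ug/mL, compound 4 is expected to show no step beyond the scatter, a step that the limit leaves unreadable from compound 3 to compound 4. Compound 4 is thus estimated at 110 ug/mL, most likely between 40 ug/mL and 300 ug/mL.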

Compound 4, half-maximal effective concentration: > 100 ug/mL
Compound 4 was reported as a limit; the forecaster's own chance of this, stated with the estimate: 65%; the middle value is on the limit's open side.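

With pyridin-4-yl on the carbonyl carbon, compound 4 in this assay gives > 100 ug/mL, which is again a limit of the measurement and not a number. Going by these compounds alone, the one step that can be read is an at least 3.0-fold higher number from compound 2 to compound 4 (0.48 log units; beyond the scatter), so a pyridine ring with its nitrogen placed differently from that in compound 3 still does not reach the effect seen with the phenethyl of compound 2. The steps from compound 1 and from compound 3 to compound 4 cannot be read, because these compounds all sit at the same limit: the limit of > 100 ug/mL in this assay, at which 3 of the 4 values shown sit.

As far as these compounds go, whether phenyl, pyridin-2-yl and pyridin-4-yl truly differ from one another in this assay stays open, as none of the three gives a number that could be compared. From the compounds shown here alone, it is also open whether the effect of compound 2 depends on the phenyl ring at the end of its chain or on the chain itself, a question that a plain butyl chain or a 2-(pyridin-4-yl)ethyl group in place of phenethyl on the carbonyl carbon could help to answer.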